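One Methyl Added to Compound 1

The source may hold more compounds than are shown below. What is called first, only, known or untested is meant among the compounds shown, and "the series" means these compounds.

Compound 1: `Clc1ccccc1COc1ccccc1/C=C/C(/C=C/c1ccccn1)=N/Oc1ncnc2ccccc12` — 95.7%
Compound 2: `Cc1cccc(COc2ccc(/C=C/C(/C=C/c3ccccn3)=N/Oc3ncnc4cccc(C)c34)cc2)c1` — 93.4%

Of the compounds shown here, two have been measured in a functional assay on SMMC-7721 cells (Homo sapiens) for inhibition, read by MTT assay, with a stated time of 72 h, tested at 1 uM; a higher number here means a stronger effect of the compound at the concentration tested, a lower number a weaker effect. Compound 1 gives 95.7%, the larger of the two numbers, and compound 2 gives 93.4%; the gap between them lies within the scatter of this assay, so the two cannot be told apart. Among the compounds with values here, no pair of measured compounds differs in only one place, so no single step has been measured.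

Compound 3, `Cc1cccc2ncnc(O/N=C(\C=C\c3ccccn3)/C=C/c3ccccc3OCc3ccccc3Cl)c12`, is not yet measured. It differs from compound 1 by methyl in place of hydrogen on an aromatic carbon. Because compound 1 already gives 95.7%, close to the top of what a percentage inhibition can reach, the expected step in this assay a number 2.7 percentage points lower from compound 1 to compound 3 (within the scatter) is small, none beyond the scatter. For compound 3 the estimated value is 93%, with an expected range from 84% to 98%.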

Compound 3, a percentage reported as inhibition, at one concentration (the size of the read-out at that concentration, not a potency): 86.8%
Beside the measured number, compound 3's estimate is 6.2 percentage points above it, within the range that was stated.
By their numbers in this assay, from the lowest: compounds 3, 2 and 1 (each within the scatter of the next).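

Within the data shown here, this is the first step measured at a single place, and in this assay it reads a number 8.9 percentage points lower from compound 1 to compound 3 (within the scatter), for the change from quinazolin-4-yl to 5-methylquinazolin-4-yl. So one methyl on this aromatic carbon leaves the inhibition indistinguishable from that of compound 1 at the one concentration tested, though a percentage at one concentration is not a potency. Nothing available explains the size of this step.

From the compounds shown here alone, whether a smaller difference in effect lies hidden at this position stays open, since both compounds sit high on a percentage scale and only a full concentration series could show it. Equally open, going by these compounds, is how a larger or different group on this same carbon, such as a methoxy group or an amine, would read in this assay.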